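The compounds below may be only part of what the source reports. "The series", "measured", "known", "first", "only" and "open" are said of these compounds alone.

Working notes on the series.

Among the measured compounds shown here, compound 1 `CCCCNc1ccnc2cc(Cl)ccc12` gives 3950 nM in a functional assay on MDA-MB-468 cells (Homo sapiens) for cytotoxicity, read by sulforhodamine B assay, with a stated time of 48 h, in the presence of a further agent that is not named here (on this read-out higher numbers stand for weaker inhibition of growth and lower numbers for stronger inhibition of growth), and stands as the highest of the two numbers measured so far; the nearest is compound 2 `CCCCNc1ccnc2cc(F)ccc12`, which gives 2690 nM in this assay. For the measured compounds named here, the one measured step, a 1.5-fold lower number from compound 1 to compound 2 (0.17 log units; within the scatter), exchanges fluoro for chloro on an aromatic carbon and lies within the scatter.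

Compound 3 `CN(C)CCNc1ccnc2cc(Cl)ccc12` is not yet measured. Relative to compound 1 the change is dimethylamino in place of ethyl on a saturated chain carbon, two bonds along the chain from a nitrogen on an aromatic ring, leaving the halogen and the shared core untouched. Going by the values given here, no measured step touches the chain on the ring nitrogen, so the step from compound 1 to compound 2 gives no guidance on the size or direction of this change. With nothing to anchor it, the expectation for compound 3 is a number near that of compound 1, the step of a 1.1-fold lower number from compound 1 to compound 3 (0.05 log units; within the scatter) expected to fall within the scatter, with a wide band. The estimate for compound 3 in this assay is 3500 nM, expected between 900 nM and 14000 nM.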

Compound 3, concentration for 50% growth inhibition: 3430 nM
Compound 3: middle estimate off by 1.0-fold (0.01 log units), on the high side, and the stated range covers the measured number.
By their numbers in this assay, from the lowest: compounds 2, 3 and 1 (each within the scatter of the next).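

Among the compounds shown here, the step of a 1.2-fold lower number from compound 1 to compound 3 (0.06 log units; within the scatter) in this assay is the first reading on the chain on the ring nitrogen; the earlier step touched only the halogen. At this place, on a saturated chain carbon two bonds along the chain from a nitrogen on an aromatic ring, dimethylamino and ethyl are not separated by this read-out, although the exchange adds a nitrogen and a hydrogen-bond acceptor by count. The same holds when the difference is read as butyl to 2-(dimethylamino)ethyl, and no data shown here bear on why the number stays within the scatter.

On these data alone, it remains open whether a longer chain carrying the dimethylamino group, or a diethylamino group or piperazine in its place, would move the number beyond the scatter. As far as these compounds go, the effect of fluoro in place of chloro on the 2-(dimethylamino)ethyl chain also remains open.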